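Urea series: cytotoxicity, carbamoyl to methoxycarbonyl

The source may report more compounds than this note shows. Statements on the series, on what has been measured and on what is new or still open speak of the compounds shown alone.

Two members of the series carry a value in an ADME assay on HEK293 cells (Homo sapiens) for cytotoxicity, with a stated time of 72 h; a higher number here means that more compound is needed for the effect, a lower number that less compound is needed. Compound 1 `Cc1cc(NC(=O)Nc2cc(F)ccc2F)c2ccccc2n1` gives 12000 nM. Compound 2 `Cc1cc(NC(=O)Nc2cccc(C(N)=O)c2)c2ccccc2n1` reaches only the limit of the assay, > 25000 nM, so no number is known for it. Compound 2 therefore stands at the bound itself, (the limit of > 25000 nM in this assay, at which 1 of the 2 values shown sits), and nothing beyond that bound can be said of where it sits. For the measured compounds named here, no step between measured compounds that differ in one place is available in this set.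

Compound 3 `COC(=O)c1cccc(NC(=O)Nc2cc(C)nc3ccccc23)c1` is not yet measured. It differs from compound 2 in one place: methoxy in place of amino on a carbonyl carbon. Going by the values given here, since compound 2 rests at a limit and no measured step sets a scale, for compound 3 no shift beyond the usual scatter of this assay is expected, a number no higher from compound 2 to compound 3 (the limit leaves the size open). Compound 3 is estimated at 25000 nM, with a range from 8000 nM to 60000 nM, and the outcome may again be only a limit.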

Compound 3, half-maximal effective concentration: 26000 nM
The estimate for compound 3 lay 1.0-fold (0.02 log units) below the measured number; the measured number falls inside the stated range.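

In this assay, for the compounds shown here, compound 2 gives > 25000 nM, which is a limit of the assay and not a number, so no step from compound 2 to compound 3 can be read. The compounds shown leave open whether carbamoyl to methoxycarbonyl changes the value at all.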